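Notes on the step from compound 1 to compound 4

This account rests on a few compounds, and the source may have more. Where it says the series, first, only, none or still open, it means among the compounds named here.

In a physicochemical assay for lipophilicity, read by HPLC, measured as chromatographic lipophilicity, at pH 7.4 (a higher number here means a more lipophilic compound, a lower number a more polar compound), compound 1 (`O=C(C1CCOC1)N1N=CCC1c1ccccc1`) gives 3 as the second highest of three numbers. Compound 3 (`CC(=O)N1CCC(C(=O)N2N=CC[C@H]2c2ccccc2)CC1`) at 2.5 lies lower and compound 2 (`O=C(C1CCN(C(=O)C(F)(F)F)CC1)N1N=CCC1c1ccccc1`) at 4.9 lies higher, both beyond the scatter from compound 1. Compound 4 (`CC(C)(CN)C(=O)N1N=CCC1c1ccccc1`) carries 1-(aminomethyl)-1-methylethyl in place of oxolan-3-yl on a carbonyl carbon. Going by the values given here, no measured pair shows a change of this kind, so the expectation rests on the structural change alone. In this assay the expected step is a number 1.40 log units lower from compound 1 to compound 4 (beyond the scatter) toward a lower number, beyond the scatter. Compound 4 is estimated at 1.6 with 0.8 as the expected lower end and 2.4 as the expected upper end.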

Compound 4, distribution coefficient: 1.4
For compound 4 the middle estimate is 0.20 log units above the measured one, and the stated range covers the measured number.
By their numbers in this assay, from the lowest: compound 4; then compound 3; then compound 1; then compound 2.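

In this assay, the place on a carbonyl carbon responds strongly to this change: 1-(aminomethyl)-1-methylethyl in place of oxolan-3-yl gives a large step, a number 1.60 log units lower from compound 1 to compound 4 (beyond the scatter). Going by these compounds alone, this is the only pair differing in one place, so it gives the only measured step at this position. No measured evidence on the origin of this step is available.

Within the data shown here, the single pair removes the ring and adds the amine together, leaving their separate contributions open. A tert-butyl group or a carboxylic acid at this place would help separate them.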